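This account rests on a few compounds, and the source may have more. Where it says the series, first, only, none or still open, it means among the compounds named here.

For the measured compounds named here, compound 2 `Cc1cc(C#N)cc(C)c1Oc1nc(Nc2ccc(C#N)cc2)ncc1-c1ccc(N)cc1` gives 310 nM in an ADME assay on MT4 cells (Homo sapiens) for cytotoxicity, read by MTT assay, with a stated time of 5 days (a lower number here means that less compound is tolerated, a higher number that more compound is tolerated), the lowest of the two numbers so far; compound 1 `Cc1cc(C#N)cc(C)c1Oc1nc(Nc2ccc(C#N)cc2)ncc1-c1ccc(Cl)cc1` gives 72600 nM in this assay. The step from compound 1 to compound 2 a 230-fold lower number from compound 1 to compound 2 (2.37 log units; beyond the scatter) is the only measured one and bears directly here. Compound 3 `Cc1cc(C#N)cc(C)c1Oc1nc(Nc2ccc(C#N)cc2)ncc1-c1ccc(C(F)(F)F)cc1` carries trifluoromethyl in place of amino on an aromatic carbon. Removing the amino that accompanied the large drop is expected to move the number back up by a large step, a 160-fold higher number from compound 2 to compound 3 (2.21 log units; beyond the scatter). Compound 3 is therefore estimated at 50000 nM, within 10000 nM to 150000 nM.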

Compound 3, half-maximal cytotoxic concentration: 35000 nM
For compound 3 the middle estimate is 1.4-fold (0.15 log units) above the measured one; low and high end bracket the measured number.
By their numbers in this assay, from the lowest: compound 2; then compound 3; then compound 1.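

In this assay the change from 4-aminophenyl to 4-(trifluoromethyl)phenyl gives a 110-fold higher number from compound 2 to compound 3 (2.05 log units; beyond the scatter), so the low number of compound 2 now stands against two other groups at this place, not against chloro alone. The two non-amino groups still differ slightly, with a 2.1-fold lower number from compound 1 to compound 3 (0.32 log units; beyond the scatter), a modest step beside those involving amino. Nothing available gives a reason for the amino result. Going by these compounds, it remains open whether the low number is specific to amino; a hydroxyl, a methylamino or an acetamido group at this place would test that.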